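The source may report more compounds than this note shows. Statements on the series, on what has been measured and on what is new or still open speak of the compounds shown alone.

Measured so far:
compound 1, `O=c1nc2oc(C3CC3)c(C#CC3CC3)c2cn1Cc1cn(Cc2ccccc2)nn1` — 6510 nM
compound 2, `CCCCCCC#Cc1c(CCCCCC)oc2nc(=O)n(Cc3cn(-c4ccc(Cl)cc4)nn3)cc12` — > 100000 nM
compound 3, `CCCCCc1ccc(C#Cc2c(-c3ccc(CCCCC)cc3)oc3nc(=O)n(Cc4cn(-c5ccc(Cl)cc5)nn4)cc23)cc1` — > 100000 nM

Among the measured compounds shown here, in a functional assay on HeLa cells (Homo sapiens) for antiproliferative activity, read by MTT assay, with a stated time of 72 h (a lower number here means a stronger inhibitor, a higher number a weaker inhibitor), compound 1 gives 6510 nM, the only real number in the set. For compound 2 the result is a limit of the assay, > 100000 nM. For compound 3 the result is likewise a limit, > 100000 nM. For the measured compounds named here, compound 1 therefore stands alone as the one compound with a measured value; the other two sit at the limit of > 100000 nM in this assay, at which 2 of the 3 values shown sit, and no single-change step between measured compounds exists.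

Compound 4, `O=c1nc2oc(C3CC3)c(C#CC3CC3)c2cn1Cc1cn(-c2ccccc2F)nn1`, differs from compound 1 by 2-fluorophenyl in place of benzyl on an aromatic nitrogen. Going by the values given here, with no measured step of this kind, a modest shift toward weaker inhibition is expected, a 2.3-fold higher number from compound 1 to compound 4 (0.36 log units; beyond the scatter). Compound 4 is estimated at 15000 nM, in the range 4000 nM to 60000 nM.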

Compound 4, half-maximal inhibitory concentration: 51200 nM
The estimate for compound 4 lay 3.4-fold (0.53 log units) below the measured number; the measured number falls inside the stated range.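

The aromatic nitrogen of the five-membered ring is sensitive in this assay: with the core of compound 1 held fixed, 2-fluorophenyl in place of benzyl gives a 7.9-fold higher number from compound 1 to compound 4 (0.90 log units; beyond the scatter). Among the compounds shown here, this is the only single-change step, and it runs towards weaker inhibition. Compound 4 still gives a real number rather than a limit of the assay, which remains the ceiling for this series: the limit of > 100000 nM in this assay, at which 2 of the 4 values shown sit.

This single step cannot separate the effect of the fluorine from that of replacing benzyl with an aryl group. Plain phenyl or 2-fluorobenzyl on this nitrogen would separate the two, while an amine or carboxylic acid on the ring remains an open question.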